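The source may hold more compounds than are shown below. What is called first, only, known or untested is meant among the compounds shown, and "the series" means these compounds.

Of the compounds shown here, two with a shared core have been measured so far. Compound 1 `COc1cc(-c2nn(-c3cccc(NC(=O)Nc4ccc(Cl)c(Cl)c4)c3)cc2-c2ccncc2)ccc1Cl` gives 1240 nM in a functional assay on HT-29 cells (Homo sapiens) for inhibition, read by sulforhodamine B assay, with a stated time of 48 h; a higher number here means a weaker inhibitor of growth, a lower number a stronger inhibitor of growth. Compound 2 `O=C(Nc1cccc(-n2cc(-c3ccncc3)c(-c3ccc(Cl)c(O)c3)n2)c1)Nc1ccc(Cl)c(Cl)c1` gives 4890 nM in this assay. Among the measured compounds shown here, the one step between them, hydrogen in place of methyl on an oxygen on an aromatic ring, produced a 3.9-fold higher number from compound 1 to compound 2 (0.60 log units; beyond the scatter). Compound 2 therefore holds the higher of the two numbers, which means it is the weaker grower-inhibitor of the pair.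

Compound 3 `O=C(Nc1cccc(-n2cc(-c3ccncc3)c(-c3ccc(Cl)c(O)c3)n2)c1)Nc1ccc(Cl)c(C(F)(F)F)c1` differs from compound 2 in one place: trifluoromethyl in place of chloro on an aromatic carbon, that is, 3,4-dichlorophenyl becomes 4-chloro-3-(trifluoromethyl)phenyl on the urea end of the molecule. For the measured compounds named here, no measured step touches this part of the structure; the only known step, from compound 1 to compound 2, concerns the oxygen on the other aromatic ring, so it offers no direct guide. With nothing in the data to suggest a move in either direction, the step of a 1.1-fold lower number from compound 2 to compound 3 (0.04 log units; within the scatter) is expected to stay within the scatter in this assay. Compound 3 is accordingly estimated at 4500 nM in this assay. The expected range for compound 3 runs from 1500 nM to 13000 nM.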

Compound 3, concentration for 50% growth inhibition: 1280 nM
Compound 3: middle estimate off by 3.5-fold (0.55 log units), on the high side; measured number below the stated range.
By their numbers in this assay, from the lowest: compounds 1 and 3 (each within the scatter of the next); then compound 2.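

This is the first change shown at the urea end of the molecule. Trifluoromethyl in place of chloro on this aromatic carbon, ortho to a chloro group, gives a 3.8-fold lower number from compound 2 to compound 3 (0.58 log units; beyond the scatter) in this assay, so compound 3 is the stronger inhibitor of growth of this pair and this position clearly affects the result. The urea end therefore matters as well as the oxygen on the other aromatic ring, where the step was a 3.9-fold higher number from compound 1 to compound 2 (0.60 log units; beyond the scatter); both steps lie beyond the scatter, although nothing available here gives a reason for the gain at the urea end.

The compounds shown leave open whether another group at this position, such as bromo, methyl or nitrile, would give a lower number still, or a higher one. They also leave open whether 4-chloro-3-(trifluoromethyl)phenyl would bring a similar gain on the core of compound 1, with its methyl on the oxygen, since the two changes appear here only as separate steps from compound 2.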